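Fluorine additions on a nucleoside analogue and cell growth

The source may hold more compounds than are shown below. What is called first, only, known or untested is meant among the compounds shown, and "the series" means these compounds.

Three nucleoside analogues sharing one core have been tested for their ability to slow cell growth. Compound 2 `Nc1ncnn2c([C@@H]3O[C@H](CO)[C@@H](O)[C@H]3O)cc(C#Cc3ccccc3)c12` carries a 2-phenylethynyl group; in a functional assay on Z-138 cells (Homo sapiens) for antiproliferative activity, with a stated time of 72 h (on this read-out higher numbers stand for weaker inhibition and lower numbers for stronger inhibition), compound 2 gives 41400 nM. Compound 1 `Nc1ncnn2c([C@@H]3O[C@H](CO)[C@@H](O)[C@H]3O)cc(C#Cc3ccc(F)cc3)c12` differs by fluoro in place of hydrogen on an aromatic carbon; in this assay compound 1 gives 89000 nM, and the step is a 2.1-fold higher number from compound 2 to compound 1 (0.33 log units; beyond the scatter). Compound 3 `Nc1ncnn2c([C@@H]3O[C@H](CO)[C@@H](O)[C@H]3O)cc(-c3ccccc3F)c12` differs from compound 2 by 2-fluorophenyl in place of 2-phenylethynyl on an aromatic carbon; in this assay compound 3 gives 95300 nM, the step being a 2.3-fold higher number from compound 2 to compound 3 (0.36 log units; beyond the scatter), while a 1.1-fold higher number from compound 1 to compound 3 (0.03 log units; within the scatter).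

Compound 4 `Nc1ncnn2c([C@@H]3O[C@H](CO)[C@@H](O)[C@H]3O)cc(-c3ccc(F)cc3F)c12` is not yet measured. It differs from compound 3 by fluoro in place of hydrogen on an aromatic carbon. This is the same kind of change as that from compound 2 to compound 1, but the place differs: here the entering fluoro is also meta to a fluoro group, which is not so on the 2-phenylethynyl group. Resting on the step from compound 2 to compound 1 a 2.1-fold higher number from compound 2 to compound 1 (0.33 log units; beyond the scatter), the step from compound 3 to compound 4 is expected to be a 1.8-fold higher number from compound 3 to compound 4 (0.25 log units; within the scatter). Compound 4 is therefore estimated to give 170000 nM, within a range from 70000 nM to 400000 nM.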

Compound 4, half-maximal inhibitory concentration: 59100 nM
The estimate for compound 4 lay 2.9-fold (0.46 log units) above the measured number; measured number outside the range, below it.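

The same fluoro in place of hydrogen does not carry over as a fixed step between the 2-phenylethynyl group and the 2-fluorophenyl group in this assay: the same change on two cores in this assay, a 2.1-fold higher number (0.33 log units; beyond the scatter) from compound 2 to compound 1 and a 1.6-fold lower number (0.21 log units; within the scatter) from compound 3 to compound 4, 3.5-fold (0.54 log units) apart, beyond the scatter of two such steps. The new step itself, a 1.6-fold lower number from compound 3 to compound 4 (0.21 log units; within the scatter), stays small, as do a 1.4-fold higher number from compound 2 to compound 4 (0.15 log units; within the scatter) and a 1.5-fold lower number from compound 1 to compound 4 (0.18 log units; within the scatter), so none of these three steps separates its two compounds on this read-out. A step taken on one core is therefore a poor guide to the same change on the other here, but this rests on a single pair of steps and does not show why the two differ or that the second fluoro truly improves growth inhibition.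

The compounds shown leave open whether the two cores would also part ways with a group other than fluoro at this place, such as chloro, methoxy or an amine. They also leave open how the change would read on a core carrying a longer chain in place of the aromatic group.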